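The source may report more compounds than this note shows. Statements on the series, on what has been measured and on what is new or still open speak of the compounds shown alone.

Measured in an ADME assay on HEK293 cells (Homo sapiens) for cytotoxicity, read by CellTiter-Glo and resazurin assay, with a stated time of 72 h; a lower number here means that less compound is needed, a higher number that more compound is needed for the effect:

- Compound 1, `CCOC(=O)CCCCCOc1ccc(CNC(C)C)cc1`: > 26000 nM
- Compound 2, `CCOC(=O)CCCCCOc1ccc(C=O)cc1`: > 26000 nM

Compound 2 stands at > 26000 nM, and this is a limit of the assay, not a number. Compound 1 shows > 26000 nM, which is the same kind of limit. Among the compounds with values here, the one measured step is a step that the two limits leave unreadable from compound 1 to compound 2, so it offers no size to carry forward.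

Compound 3, `CCOC(=O)CCCCCOc1ccc(CO)cc1`, has hydroxymethyl in place of formyl on an aromatic carbon, and the change is counted here: hydroxymethyl in place of formyl on an aromatic carbon.

Within the data shown here, the only guide is that compound 1 and compound 2 carry different groups at this place and neither gives a number in this assay. The evidence is the limit of > 26000 nM in this assay, at which 2 of the 2 values shown sit. Compound 3 is therefore expected to stay at that limit too, with no readable change in either direction from compound 2. In numbers, the expected change is a step that the limit leaves unreadable from compound 2 to compound 3. For compound 3 the estimated value is 30000 nM, with an expected range from 15000 nM to 60000 nM.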

Compound 3, half-maximal effective concentration: > 27100 nM
Compound 3 was reported as a limit (the forecaster's own chance of this, stated with the estimate: 85%); the middle value does not contradict the limit.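

In this assay compound 3 gives > 27100 nM as a limit of the assay, not a number. Compound 1 and compound 2 also stand at limits, so the steps from either of them to compound 3 cannot be read. The compounds shown leave open whether any group at this place gives a measurable value.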